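Morpholin-4-yl in place of ethoxy on a carbonyl carbon

A few compounds are considered here, and "the series" means these few. Any claim that something is new, unique, unknown or untested is made for them only; others in the source may bear on it.

In a functional assay on MCF7 cells (Homo sapiens) for inhibition, read by sulforhodamine B assay, with a stated time of 72 h (a lower number here means a stronger inhibitor of growth, a higher number a weaker inhibitor of growth), compound 2 (`CCOC(=O)/C=C/c1ccncc1-c1ccc2cc[nH]c2c1`) gives 6880 nM and compound 1 (`CNC(=O)/C=C/c1ccncc1-c1ccc2cc[nH]c2c1`) gives 9230 nM, so these two values lie within the scatter of each other. Compound 3 (`O=C(O)/C=C/c1ccncc1-c1ccc2ccccc2c1`) gives > 10000 nM, which is a limit and not a number. That leaves compound 2 level with compound 1 among the numbers available, and the limit of > 10000 nM in this assay, at which 1 of the 3 values shown sits, is the only other mark.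

Compound 4 (`O=C(/C=C/c1ccncc1-c1ccc2cc[nH]c2c1)N1CCOCC1`) carries morpholin-4-yl in place of ethoxy on a carbonyl carbon. Among the compounds with values here, the one measured step at this carbonyl carbon is a 1.3-fold lower number from compound 1 to compound 2 (0.13 log units; within the scatter), with ethoxy in place of methylamino, and it stays within the scatter. Compound 1 thus offers no sign of a large effect from exchanging the group at this place, though morpholin-4-yl itself has not been tested in this assay. The expected change is a 1.2-fold higher number from compound 2 to compound 4 (0.09 log units; within the scatter), a small rise in the number that is not expected to exceed the scatter. For compound 4 the estimated value is 8500 nM, with an expected range of 4000 nM to 16000 nM.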

Compound 4, concentration for 50% growth inhibition: > 10000 nM
Compound 4 gave a limit, no number; the forecaster's own chance of this, stated with the estimate: 35%; at least 1.1-fold (0.07 log units) between middle value and limit.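

In this assay compound 4 gives > 10000 nM, which is a limit and not a number. The steps read an at least 1.4-fold higher number from compound 2 to compound 4 (0.16 log units; that floor lies within the scatter) and an at least 1.0-fold higher number from compound 1 to compound 4 (0.03 log units; that floor lies within the scatter), so neither floor shows a loss beyond the scatter, but morpholin-4-yl does not bring the number down at this carbonyl carbon. This is the first ring at this place among the compounds shown, and it leaves compound 4 at the top of the measurable range: the limit of > 10000 nM in this assay, at which 2 of the 4 values shown sit.

Going by these compounds, how far past the limit compound 4 lies stays open, so whether this exchange truly weakens growth inhibition cannot be told. Also open, on these data alone, is how a piperidine ring, or an amine on a longer chain, would behave on this carbonyl carbon of the shared core.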